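The compounds below may be only part of what the source reports. "The series", "measured", "known", "first", "only" and "open" are said of these compounds alone.

Working notes on the series.

Of the compounds shown here, two have numbers so far. Compound 1 `C[C@H](NC(=O)Nc1ccc(C(C)(C)C)cc1)c1ccccc1` gives 64% in an ADME assay on the whole organism with Oryza sativa as the target, tested at 10 uM; on this read-out lower numbers stand for a stronger effect and higher numbers for a weaker effect at the one concentration tested. Compound 2 `CCCCCCc1ccc(NC(=O)N[C@@H](C)c2ccccc2)cc1` gives 99% in this assay, the highest of the two numbers shown, with compound 1 the nearest and lower. For the measured compounds named here, the one measured step, hexyl in place of tert-butyl on an aromatic carbon, is a number 35 percentage points higher from compound 1 to compound 2 (beyond the scatter).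

Compound 3 `C[C@H](NC(=O)Nc1ccc(F)cc1)c1ccccc1` is next for this assay. Its change from compound 2 is fluoro in place of hexyl on an aromatic carbon; the group sits on an aromatic carbon of a six-membered aromatic ring of carbon only.

Going by the values given here, only the step from compound 1 to compound 2 bears on this, and it concerns a different pair of groups, so it gives no direct guide to fluoro. It does show that a change at this position can move the number by a large amount. With the tert-butyl compound 1 lower than the hexyl compound 2, the expectation for compound 3 is a number below compound 2, a step of a number 29 percentage points lower from compound 2 to compound 3 (beyond the scatter), with wide uncertainty. Compound 3 is estimated at 70%, in a range from 40% to 100%.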

Compound 3, a percentage reported as activity, at one concentration (the size of the read-out at that concentration, not a potency): 85%
Compound 3: middle estimate off by 15 percentage points, on the low side, and the stated range covers the measured number.
By their numbers in this assay, from the lowest: compound 1; then compound 3; then compound 2.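

In this assay, fluoro in place of hexyl on the aromatic carbon gives a number 14 percentage points lower from compound 2 to compound 3 (beyond the scatter), and fluoro in place of tert-butyl gives a number 21 percentage points higher from compound 1 to compound 3 (beyond the scatter). The position therefore now has three points that are all separated beyond the scatter: fluoro falls between the two carbon groups, and tert-butyl keeps the lowest number of the three. Hexyl to fluoro removes carbon atoms and lowers the number, yet fluoro, with fewer heavy atoms than hexyl, does not reach the number of compound 1, so group size alone does not set the order here, and nothing at hand explains this order.

Three groups at one position do not show which feature of the group governs the number, and a shorter chain such as ethyl, a branched chain such as isopropyl, or a methoxy, amine or carboxylic acid group at the same place would test whether the order extends beyond these compounds. As far as these compounds go, whether the same order holds with the other parts of the shared core changed also remains open.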